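The source may report more compounds than this note shows. Statements on the series, on what has been measured and on what is new or still open speak of the compounds shown alone.

Compound 1 `CCOc1ccc(NC(=O)c2cccc(/C=C3\CC(=O)N(c4ccccc4)C3=O)c2)cc1` is the starting point of this account. In an ADME assay on SW480 cells (Homo sapiens) for cytotoxicity, read by MTT assay, with a stated time of 72 h (a higher number here means a weaker inhibitor, a lower number a stronger inhibitor), compound 1 gives 91500 nM, the highest of the two numbers available. Its nearest neighbour is compound 3 `CCc1cccc(NC(=O)c2cccc(/C=C3\CC(=O)N(c4ccc(C)cc4)C3=O)c2)c1`, which in this assay gives 65300 nM; the gap between the two lies within the scatter, so no order between them can be read. Compound 2 `CCCCCN1C(=O)C/C(=C\c2cccc(C(=O)NCCCC)c2)C1=O` returns only a limit of the assay in this assay, namely > 100000 nM. This is the limit of > 100000 nM in this assay, at which 1 of the 3 values shown sits.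

The step under study leads to compound 4 `O=C(c1cccc(/C=C2\CC(=O)N(c3ccccc3)C2=O)c1)N1CCCC1`, not yet measured in this assay. The change is pyrrolidin-1-yl in place of (4-ethoxyphenyl)amino on a carbonyl carbon. For the measured compounds named here, no step between measured compounds of this set is known, and all three values gathered so far sit at the weak end of this assay, so there is no measured guide to the size of this step. The step of a 1.0-fold higher number from compound 1 to compound 4 (0.02 log units; within the scatter) is expected to be small, if anything toward a higher number, and probably within the scatter. Compound 4 is therefore estimated at 95000 nM in this assay, with a likely range from 40000 nM to 200000 nM, and with a real chance that only a limit is reported for it.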

Compound 4, half-maximal inhibitory concentration: > 100000 nM
Compound 4: a limit, no number; the forecaster's own chance of this, stated with the estimate: 45%; at least 1.0-fold (0.02 log units) between middle value and limit.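

For the compounds shown here, compound 4 is the first compound in this set with a single change from a measured partner, and in this assay it returns only a limit, > 100000 nM. The change from (4-ethoxyphenyl)amino to pyrrolidin-1-yl on a carbonyl carbon, which removes the aromatic ring and the amide hydrogen of that group, reads as an at least 1.0-fold higher number from compound 1 to compound 4 (0.03 log units; that floor lies within the scatter), so it brings no gain in potency, but the data cannot show that it costs any, since the floor of the step stays within the scatter. The position therefore tolerates this exchange without giving a number that can be ranked, and compound 4 now sits with compound 2 at the top of the range: the limit of > 100000 nM in this assay, at which 2 of the 4 values shown sit.

From the compounds shown here alone, what stays open is how far compound 4 lies past that limit, and so whether the true step from compound 1 is small or large. Going by these compounds, it is also open which of the two parts lost with the (4-ethoxyphenyl)amino group matters here, and whether a phenylamino group or a morpholin-4-yl group on the same carbonyl carbon would give a number within the range of the assay.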